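This account rests on a few compounds, and the source may have more. Where it says the series, first, only, none or still open, it means among the compounds named here.

Compound 1 `CC1CCN(c2c(S(=O)(=O)c3cccc(Cl)c3)cnc3cc(Cl)ccc23)CC1` is one of three compounds examined in an assay on isolated protein for displacement of a labelled ligand from metabotropic glutamate receptor 5 (Homo sapiens), with a stated time of 60 min, tested at 1 uM (on this read-out higher numbers stand for more inhibition at the one concentration tested (going by the name of the read-out) and lower numbers for less inhibition), where compound 1 gives 92%. Its companions are compound 2 `Cc1ccc2ncc(S(=O)(=O)c3ccc(Cl)c(Cl)c3)c(N3CCC(C)CC3)c2c1`, which in this assay gives 82%, and compound 3 `Cc1ccc2ncc(S(=O)(=O)c3cccc(F)c3)c(N3CCC(C)CC3)c2c1`, which gives 94%. Compound 1 sits second of the three, but both gaps to it lie within the scatter, so no order among the three can be read from these numbers.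

Among the compounds with values here, the one measured step, a number 12 percentage points higher from compound 2 to compound 3 (beyond the scatter), swaps the ring attached to the sulfonyl sulfur and is modest in size. Compound 4 `COc1ccc(S(=O)(=O)c2cnc3cc(Cl)ccc3c2N2CCC(C)CC2)cc1` changes the same position of compound 1: 4-methoxyphenyl in place of 3-chlorophenyl on a sulfonyl sulfur. That step bears on the present question only loosely, since it involves different groups and the two compounds share a core that differs from that of compound 1 in one substituent. A swap of this kind has so far moved the read-out modestly or not at all, so for compound 4 the expected step of a number 7 percentage points lower from compound 1 to compound 4 (within the scatter) is small and uncertain in direction. Compound 4 is therefore estimated at 85%, most likely between 62% and 97%.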

Compound 4, a percentage reported as inhibition, at one concentration (the size of the read-out at that concentration, not a potency): 79%
Estimate against measurement, compound 4: 6 percentage points above; low and high end bracket the measured number.
By their numbers in this assay, from the lowest: compounds 4, 2, 1 and 3 (each within the scatter of the next, the first and the last beyond it).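

In this assay, placing 4-methoxyphenyl on the sulfonyl sulfur in place of 3-chlorophenyl gives a number 13 percentage points lower from compound 1 to compound 4 (beyond the scatter). Within the data shown here, the earlier step at this position involved a different core, so this is the first evidence that the ring on the sulfur also affects the read-out on the core of compound 1. No measured evidence explains the change, although 4-methoxyphenyl counts one hydrogen-bond acceptor and 3-chlorophenyl none.

The compounds shown leave open whether the step follows from the methoxy group itself or from where it sits on the ring, as the two change together here. Also open, from the compounds shown here alone, is how this position responds to a cyclohexyl ring on the sulfur, or to a phenyl ring carrying an amine or a carboxylic acid.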